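The source may report more compounds than this note shows. Statements on the series, on what has been measured and on what is new or still open speak of the compounds shown alone.

Working notes on the series. Of the compounds shown here, three have been measured so far in a functional assay on ECV-304 cells (Homo sapiens), read by MTT assay, with stated times of 24 h and 12 h, tested at 25 uM; on this read-out higher numbers stand for a stronger effect at the one concentration tested and lower numbers for a weaker effect. Compound 1, `Cc1nc(C)c(CNC(=O)CN2CCCC2=O)nc1C`, gives 14.5%. Compound 2, `Cc1nc(C)c(COc2ccc3c(C)cc(=O)oc3c2)nc1C`, gives 21%. Compound 3, `Cc1nc(C)c(CSc2nnc(-c3cccs3)n2N)nc1C`, gives 37.4%, the highest of the three numbers; its nearest neighbour is compound 2, whose number lies beyond the scatter below it, and its furthest is compound 1, whose number also lies beyond the scatter below it. Within these three no pair of compounds differs in one place only, so no single step between measured compounds is available.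

The next compound is compound 4, `Cc1nc(C)c(CSc2nnc(-c3ccco3)n2N)nc1C`, which differs from compound 3 in one place: furan-2-yl in place of thiophen-2-yl on an aromatic carbon. Within the data shown here, no measured pair in this set shows what such an exchange does in this assay, so the expectation rests on compound 3 alone. The step from compound 3 to compound 4 is expected to be small, a number 3.4 percentage points lower from compound 3 to compound 4 (within the scatter), and not beyond the scatter in either direction. Compound 4 is therefore estimated at 34%, with a range from 21% to 47%.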

Compound 4, a percentage reported as activity, at one concentration (the size of the read-out at that concentration, not a potency): 21.3%
Compound 4: the middle estimate sits 12.7 percentage points above what was measured; measured number inside the range.
By their numbers in this assay, from the lowest: compounds 1, 2 and 4 (each within the scatter of the next); then compound 3.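

Among these compounds, the first single-place step falls on an aromatic carbon of the five-membered aromatic ring with 3 nitrogen: in this assay, furan-2-yl in place of thiophen-2-yl gives a number 16.1 percentage points lower from compound 3 to compound 4 (beyond the scatter) at this position. The exchange replaces only the ring sulfur with oxygen, leaving the heavy-atom count and the counted hydrogen-bond donors and acceptors unchanged, and that is enough to move the number beyond the scatter. Nothing measured here accounts for the size or direction of this step.

The compounds shown leave open how phenyl, pyridin-2-yl or methyl would read on this same carbon. They also leave open whether the furan-2-yl for thiophen-2-yl exchange would give a similar step with a methyl group in place of the amino group on the ring.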